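From 3-chlorophenyl to 2-bromophenyl in a cytotoxicity series

The compounds below may be only part of what the source reports. "The series", "measured", "known", "first", "only" and "open" are said of these compounds alone.

In a functional assay on HT-1080 cells (Homo sapiens) for cytotoxicity, read by MTT assay, with a stated time of 72 h (on this read-out lower numbers stand for stronger inhibition and higher numbers for weaker inhibition), compound 1 (`COc1ccccc1/C=C1\CCC/C(=C\c2cccc(OC)c2OC)C1=O`) gives 14100 nM. Compound 2 (`COc1ccc(/C=C2\CCC/C(=C\c3ccccc3Cl)C2=O)cc1OC`) gives 6800 nM. Compound 3 (`COc1ccc(/C=C2\CCC/C(=C\c3cccc(Cl)c3)C2=O)cc1OC`) gives 4900 nM, clearly under the number for compound 1 and level with compound 2 within the scatter. Compound 4 (`COc1ccc(/C=C2\CCC/C(=C\c3ccccc3Br)C2=O)cc1OC`) carries 2-bromophenyl in place of 3-chlorophenyl on a double-bonded chain carbon bound to a double-bonded ring carbon. Among the compounds with values here, the one measured step that bears on this is a 1.4-fold lower number from compound 2 to compound 3 (0.14 log units; within the scatter). No exchange of chlorine for bromine has been measured, but 2-bromophenyl matches the 2-chlorophenyl of compound 2 at 6800 nM, the nearest guide. A step of a 1.3-fold higher number from compound 3 to compound 4 (0.12 log units; within the scatter) is therefore expected, nothing beyond the scatter. The estimate for compound 4 is 6500 nM, with an expected range of 3300 nM to 12500 nM.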

Compound 4, half-maximal inhibitory concentration: 8400 nM
Estimate against measurement, compound 4: 1.3-fold (0.11 log units) below, and the stated range covers the measured number.
By their numbers in this assay, from the lowest: compounds 3, 2, 4 and 1 (each within the scatter of the next, the first and the last beyond it).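

In this assay, the direct exchange of halogen, bromo in place of chloro on an aromatic carbon, gives a 1.2-fold higher number from compound 2 to compound 4 (0.09 log units; within the scatter), and the change from 3-chlorophenyl to 2-bromophenyl gives a 1.7-fold higher number from compound 3 to compound 4 (0.23 log units; within the scatter). Both steps stay within the scatter, so this assay does not separate these three halogen-bearing phenyl groups on a double-bonded chain carbon bound to a double-bonded ring carbon. Nothing available here offers an explanation for this. Still open, going by these compounds, is whether an amine or a carboxylic acid on that phenyl ring, in place of the halogen, would shift the number beyond the scatter.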